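Sulfonyl aryl replacement in a pyridopyrimidinone series

This account rests on a few compounds, and the source may have more. Where it says the series, first, only, none or still open, it means among the compounds named here.

Three compounds of this series have numbers in a functional assay on DU-145 cells (Homo sapiens) for inhibition, read by trypan blue exclusion, with a stated time of 72 h; on this read-out lower numbers stand for stronger inhibition and higher numbers for weaker inhibition. Compound 1 `Cn1c(=O)c(S(=O)(=O)c2ccc(C(=O)O)cc2)cc2cnc(Nc3ccc4[nH]ccc4c3)nc21` gives 10000 nM in this assay. Compound 2 `Cc1ccc(S(=O)(=O)c2cc3cnc(Nc4ccc5cc[nH]c5c4)nc3n(C)c2=O)cc1` gives 15000 nM in this assay, and compound 3 `COC(=O)Cn1ccc2cc(Nc3ncc4cc(S(=O)(=O)c5ccc(F)cc5F)c(=O)n(C)c4n3)ccc21` gives 5000 nM in this assay. The number of compound 1 stands between those of compound 2 and compound 3, yet both gaps are within the scatter, so the three compounds cannot be told apart on these data; all three sit at weak inhibition.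

Compound 4 `Cn1c(=O)c(S(=O)(=O)c2ccc(N)cc2F)cc2cnc(Nc3ccc4[nH]ccc4c3)nc21` is not yet measured. It differs from compound 1 in one place: 4-amino-2-fluorophenyl in place of 4-carboxyphenyl on a sulfonyl sulfur. For the measured compounds named here, no measured pair differs in one place, so no step can be taken as a guide, and the spread among compound 1, compound 2 and compound 3 is narrow although their sulfonyl aryl groups differ.

The expectation for compound 4 is therefore a step from compound 1 that stays within the scatter, if anything toward a slightly lower number, as a 1.4-fold lower number from compound 1 to compound 4 (0.15 log units; within the scatter). Compound 4 is estimated at 7000 nM in this assay, with a range from 2500 nM to 20000 nM.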

Compound 4, half-maximal inhibitory concentration: 8000 nM
The estimate for compound 4 lay 1.1-fold (0.06 log units) below the measured number; the range from low to high includes it.
By their numbers in this assay, from the lowest: compounds 3, 4, 1 and 2 (each within the scatter of the next, the first and the last beyond it).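

For the compounds shown here, this is the first step that changes only one place, and in this assay it reads a 1.3-fold lower number from compound 1 to compound 4 (0.10 log units; within the scatter). With the rest of compound 1 held fixed, 4-amino-2-fluorophenyl and 4-carboxyphenyl on a sulfonyl sulfur cannot be told apart, so at this position the carboxylic acid can give way to an aryl group carrying an amine and a fluorine with the two numbers staying within the scatter. Going by these compounds alone, no measurement here accounts for this result, and the single step gives no reason for it.

A single step at weak inhibition does not show whether any replacement at this position can give a difference beyond the scatter. Still open, from the compounds shown here alone, are a plain 4-aminophenyl without the fluorine, which would separate the amine from the fluorine, a 4-carboxamidophenyl, which would keep the carbonyl without the acid, and a methyl on the sulfonyl sulfur in place of the aryl ring.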